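Trading 3,4-dichlorobenzyl for acetyl

A few compounds are considered here, and "the series" means these few. Any claim that something is new, unique, unknown or untested is made for them only; others in the source may bear on it.

In a physicochemical assay for solubility, with a stated time of 3 days, at pH 7 (a higher number here means a more soluble compound, a lower number a less soluble compound), compound 2 `NC(=O)c1ccc2[nH]c(-c3ccc(OCCC4CCCCN4Cc4ccc(Cl)c(Cl)c4)cc3)nc2c1` gives 229000 nM. Among the measured compounds shown here, the entry for compound 1 `NC(=O)c1ccc2[nH]c(-c3ccc(OCC4CCCNC4)cc3)nc2c1` reads "not determined" (no result reported), so compound 2 holds the only number so far and has nothing to be ranked against. Compound 3 `CC(=O)N1CCCCC1CCOc1ccc(-c2nc3cc(C(N)=O)ccc3[nH]2)cc1` carries acetyl in place of 3,4-dichlorobenzyl on an amine nitrogen in a ring. For the measured compounds named here, no measured step exists to show what such a swap does, so the estimated step of a 1.5-fold lower number from compound 2 to compound 3 (0.18 log units; within the scatter) is expected to stay within the usual scatter. For compound 3 the estimated value is 150000 nM, expected to fall between 30000 nM and 500000 nM.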

Compound 3, solubility: 193000 nM
Beside the measured number, compound 3's estimate is 1.3-fold (0.11 log units) below it, and the stated range covers the measured number.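

In this assay, acetyl in place of 3,4-dichlorobenzyl gives a 1.2-fold lower number from compound 2 to compound 3 (0.07 log units; within the scatter) on an amine nitrogen in a ring. Among the compounds shown here, this is the first measured step at this position, and it shows that a group of 9 heavy atoms with an aromatic ring and a group of 3 heavy atoms with no ring read alike here, for this one pair. No supporting measurement bears on this result. Open, on these data alone, is how methyl or methylsulfonyl on this nitrogen would read in this assay. Also open, as far as these compounds go, is whether this swap would read the same way on a longer chain.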